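Methylsulfonyl for methylsulfanyl beside an imidazoline anilinomethyl

A few compounds are considered here, and "the series" means these few. Any claim that something is new, unique, unknown or untested is made for them only; others in the source may bear on it.

Two members of this series have been examined in an assay on CHO cells for binding affinity to Alpha-2C adrenergic receptor (Homo sapiens), read by radioligand binding; a higher number here means a weaker inhibitor, a lower number a stronger inhibitor. Compound 1, `COc1ccc(S(C)(=O)=O)c(NCC2=NCCN2)c1`, carries a methylsulfonyl group on its core and in this assay reaches only a limit, < 5020 nM, rather than a number. For the measured compounds named here, compound 2, `CSc1ccc(C(F)(F)F)cc1NCC1=NCCN1`, bears a methylsulfanyl group and a trifluoromethyl group and gives 603 nM in this assay, the only number among the two values shown. The other value belongs to compound 1, which stands at the limit noted in the limit of < 5020 nM in this assay, at which 1 of the 2 values shown sits. Going by the values given here, no step between measured compounds is available, since compound 1 and compound 2 differ in more than one place.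

Compound 3, `CS(=O)(=O)c1ccc(C(F)(F)F)cc1NCC1=NCCN1`, is not yet measured. It differs from compound 2 in one place: methylsulfonyl in place of methylsulfanyl on an aromatic carbon. Among the compounds with values here, with no measured step to guide it, the expectation for compound 3 in this assay is a step toward weaker binding of a 2.5-fold higher number from compound 2 to compound 3 (0.40 log units; beyond the scatter), which is expected to leave compound 3 near 1500 nM, estimated within the range from 400 nM to 6000 nM.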

Compound 3, inhibition constant: < 5020 nM
Compound 3 was reported as a limit; the forecaster's own chance of this, stated with the estimate: 25%; the middle value lies beyond the limit too.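

Compound 3 is reported only as a limit in this assay, and neither the step to it from compound 2 nor the step to it from compound 1 can be read. The compounds shown leave open what number compound 3 would take, and with it how far methylsulfonyl in place of methylsulfanyl on an aromatic carbon shifts binding in this assay.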